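The source may report more compounds than this note shows. Statements on the series, on what has been measured and on what is new or still open speak of the compounds shown alone.

Compound 3 `CCn1nc(-n2ccnc2)c2ccccc2c1=O` is the point of departure here. Within the data shown here, in an assay on isolated protein (Oryctolagus cuniculus) with Thromboxane-A synthase (Homo sapiens) as the target, tested at 1 uM (a higher number here means more inhibition at the concentration tested (going by the name of the read-out), a lower number less inhibition), compound 3 gives 53%, the lowest of the three numbers known so far. Its nearest neighbour is compound 1 `COCCn1nc(-c2cccnc2)c2ccccc2c1=O`, which in this assay gives 55%, a value within the usual scatter of that of compound 3, so the two cannot be told apart. Compound 2 `COC(=O)c1ccc(Cn2nc(-c3cccnc3)c3ccccc3c2=O)cc1` gives 95% in this assay, clearly beyond the scatter above compound 3. Compound 4 `CCn1nc(-c2cncnc2)c2ccccc2c1=O` has not been measured; it differs from compound 3 in one place: pyrimidin-5-yl in place of 1H-imidazol-1-yl on an aromatic carbon. Among the measured compounds shown here, no measured pair shows this change, so no step can be read off. The step from compound 3 to compound 4 is expected to be small, a number 8 percentage points lower from compound 3 to compound 4 (within the scatter), and not clearly beyond the scatter. Compound 4 is therefore estimated to give 45% in this assay, within a range from 20% to 70%.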

Compound 4, a percentage reported as inhibition, at one concentration (the size of the read-out at that concentration, not a potency): 26%
Beside the measured number, compound 4's estimate is 19 percentage points above it, and the stated range covers the measured number.
By their numbers in this assay, from the lowest: compound 4; then compounds 3 and 1 (each within the scatter of the next); then compound 2.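

Among these compounds, with the ethyl group held constant, the swap of 1H-imidazol-1-yl for pyrimidin-5-yl in this assay gives a number 27 percentage points lower from compound 3 to compound 4 (beyond the scatter), the first single-place change that can be read at this aromatic carbon. The result shows that this position is sensitive to which ring it carries, even though both rings count two nitrogens and the same hydrogen-bond donors and acceptors. Nothing available explains the drop. The compounds shown leave open how a plain phenyl ring or an amine would fare on this carbon, and whether a longer chain in place of the ethyl group would change the outcome.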